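Fluoro in place of methoxy: compound 3 to compound 4

The compounds below may be only part of what the source reports. "The series", "measured", "known", "first", "only" and "open" are said of these compounds alone.

Of the compounds shown here, three have been read in a functional assay on RAW264.7 cells (Mus musculus) for inhibition, with stated times of 2 h and 24 h; on this read-out higher numbers stand for weaker inhibition and lower numbers for stronger inhibition. Compound 1 (`COc1ccc([C@@H]2c3c(OC)cc(OC)cc3C(=O)[C@H]2c2cc(OC)cc(OC)c2)cc1`) gives > 200000 nM, which is a limit of the assay and not a number. Compound 2 (`COc1cc(OC)cc([C@@H]2/C(=C\c3ccccc3)c3cc(OC)cc(OC)c3[C@H]2c2ccccc2)c1`) gives > 200000 nM, again a limit. For the measured compounds named here, compound 3 (`COc1ccc([C@@H]2c3c(OC)cc(OC)cc3C(O)[C@H]2c2cc(OC)cc(OC)c2)cc1`) gives 7870 nM, the only actual number so far, so its standing against the other two cannot be sized as a step.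

Compound 4 (`COc1cc(OC)cc([C@@H]2C(O)c3cc(OC)cc(OC)c3[C@H]2c2ccc(F)cc2)c1`) is the next to be read. It has fluoro in place of methoxy on an aromatic carbon, para to a large group, so that 4-methoxyphenyl becomes 4-fluorophenyl: fluoro in place of methoxy on an aromatic carbon. Going by the values given here, no measured pair tests this change. Among the compounds with values here, with compound 3 at 7870 nM as the only number to build on, no step beyond the scatter is expected in this assay, in either direction. The estimated step is a 1.1-fold higher number from compound 3 to compound 4 (0.06 log units; within the scatter). For compound 4 the expected value is 9000 nM, with an estimated range of 2500 nM to 35000 nM.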

Compound 4, half-maximal inhibitory concentration: "not active" (no number reported)
For compound 4 the study gives words and no number, so the estimate cannot be set against anything.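

For the compounds shown here, compound 4 is reported in this assay in words and without a number, so no step from compound 3 to compound 4 can be read. Left open is what 4-fluorophenyl in place of 4-methoxyphenyl does to the read-out, and whether compound 4 stands with the compounds at the limit: the limit of > 200000 nM in this assay, at which 2 of the 4 values shown sit.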